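A few compounds are considered here, and "the series" means these few. Any claim that something is new, unique, unknown or untested is made for them only; others in the source may bear on it.

Compound 3 `CN(C)c1ncnc(-c2cc(Cl)ccc2NS(=O)(=O)c2ccc(C(C)(C)C)cc2)c1O` gives 9 nM in a functional assay on isolated protein for antagonist activity at C-C chemokine receptor type 9 (Homo sapiens), read by calcium flux, with a stated time of 10 min (a lower number here means a stronger inhibitor, a higher number a weaker inhibitor), the lowest number of the three compounds measured there. Compound 1 `COc1ccnc(-c2cc(Cl)ccc2NS(=O)(=O)c2ccc(C(C)(C)C)cc2)c1` gives 2500 nM in this assay, and compound 2 `CC(C)(C)c1ccc(S(=O)(=O)Nc2ccc(Cl)cc2-c2ncccc2CO)cc1` gives 89 nM. Every measured step here changes the same aromatic ring on the shared core: there was a 28-fold lower number from compound 1 to compound 2 (1.45 log units; beyond the scatter), then a 9.9-fold lower number from compound 2 to compound 3 (1.00 log units; beyond the scatter), and across both a 280-fold lower number from compound 1 to compound 3 (2.44 log units; beyond the scatter). For the measured compounds named here, compound 4 `CNc1nccnc1-c1cc(Cl)ccc1NS(=O)(=O)c1ccc(C(C)(C)C)cc1` again changes only that ring, with a group of 8 heavy atoms (5 carbon, 3 nitrogen; one six-membered aromatic ring with 2 hetero atoms) in place of a group of 10 heavy atoms (6 carbon, 3 nitrogen, 1 oxygen; one six-membered aromatic ring with 2 hetero atoms), on an aromatic carbon. The measured steps show that this ring governs the numbers strongly, and that the ring of compound 3 beats both alternatives tried. Since the incoming ring of compound 4 is a further untested variant, and the two earlier variants both gave higher numbers than compound 3, a weaker result is expected, though the move from compound 2 to compound 3 suggests the loss need not be large. The estimate for compound 4 is 50 nM, within 10 nM to 300 nM, which is expected to mean a 5.6-fold higher number from compound 3 to compound 4 (0.74 log units; beyond the scatter).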

Compound 4, half-maximal inhibitory concentration: 25 nM
For compound 4 the middle estimate is 2.0-fold (0.30 log units) above the measured one, and the stated range covers the measured number.
By their numbers in this assay, from the lowest: compound 3; then compound 4; then compound 2; then compound 1.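

In this assay, the 3-(methylamino)pyrazin-2-yl group shows that a low number at this position does not depend on the exact ring of compound 3, although there is still a modest loss, with a 2.8-fold higher number from compound 3 to compound 4 (0.44 log units; beyond the scatter). The new ring also improves on both pyridine rings, giving a 3.6-fold lower number from compound 2 to compound 4 (0.55 log units; beyond the scatter) and a 100-fold lower number from compound 1 to compound 4 (2.00 log units; beyond the scatter). Among these four compounds, the two with a six-membered aromatic ring holding 2 hetero atoms therefore give lower numbers than the two with 1 hetero atom, and none goes against this order.

No measurement is available that explains these differences. As far as these compounds go, it remains open how the number would respond if the methylamino group of compound 4 were replaced by a plain amine or a longer ethylamino chain.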